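Swapping the small ring on the sulfur of compound 3

The source may hold more compounds than are shown below. What is called first, only, known or untested is meant among the compounds shown, and "the series" means these compounds.

Measured compounds and their values in a functional assay on HT-29 cells (Homo sapiens) for cytotoxicity, read by MTT assay, with a stated time of 24 h, tested at 32 ug/mL; a higher number here means a stronger effect of the compound at the concentration tested, a lower number a weaker effect:
compound 1 `Cn1c(-c2ccc(NC(=O)CSc3nc4cc(Cl)ccc4o3)cc2)nc(-c2ccccc2)c1-c1ccccc1` gives 61.9%
compound 2 `Cn1c(-c2ccc(NC(=O)CSc3nc4ccccc4s3)cc2)nc(-c2ccccc2)c1-c1ccccc1` gives 66%
compound 3 `Cn1cnnc1SCC(=O)Nc1ccc(-c2nc(-c3ccccc3)c(-c3ccccc3)n2C)cc1` gives 86.1%

Compound 3 stands highest of the three in this assay, and its lead over compound 2 and compound 1 is beyond the scatter in both cases. The unmeasured compound 4 `Cc1nnc(SCC(=O)Nc2ccc(-c3nc(-c4ccccc4)c(-c4ccccc4)n3C)cc2)s1` differs from compound 3 in a single place: 5-methyl-1,3,4-thiadiazol-2-yl in place of 4-methyl-4H-1,2,4-triazol-3-yl on a sulfur.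

For the measured compounds named here, two measured steps touch the same sulfur and so bear on this change. Replacing the larger ring of compound 1 by the small ring of compound 3 gave a number 24.2 percentage points higher from compound 1 to compound 3 (beyond the scatter), and the corresponding replacement from compound 2 gave a number 20.1 percentage points higher from compound 2 to compound 3 (beyond the scatter). Both gains came from exchanging a bicyclic group for a small five-membered ring. Going by the values given here, the change into compound 4 keeps a small five-membered ring and only rearranges its atoms, so there is no measured step of this kind; the expectation is a step near zero, within the scatter, with the risk that some of the gain seen on going to compound 3 is lost. Compound 4 is therefore estimated to give 79%, between 62% and 92%, which means an expected step of a number 7.1 percentage points lower from compound 3 to compound 4 (within the scatter).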

Compound 4, a percentage reported as activity, at one concentration (the size of the read-out at that concentration, not a potency): 87.1%
For compound 4 the middle estimate is 8.1 percentage points below the measured one; low and high end bracket the measured number.
By their numbers in this assay, from the lowest: compounds 1 and 2 (each within the scatter of the next); then compounds 3 and 4 (each within the scatter of the next).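

In this assay the step between the two small rings is a number 1 percentage points higher from compound 3 to compound 4 (within the scatter), so on this sulfur, 5-methyl-1,3,4-thiadiazol-2-yl and 4-methyl-4H-1,2,4-triazol-3-yl cannot be told apart, even though one ring nitrogen gives way to a ring sulfur at the same count of heavy atoms. The advantage over the two bicyclic groups is therefore not tied to the triazole alone: the thiadiazole also stands clear of them, with a number 21.1 percentage points higher from compound 2 to compound 4 (beyond the scatter) and a number 25.2 percentage points higher from compound 1 to compound 4 (beyond the scatter), and none of the four compounds goes against this. No measured property of these groups bears on the result, so the data offer no explanation for it.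

As far as these compounds go, all four compounds carry an aromatic ring on this sulfur, so what a saturated piperidine ring or a longer alkyl chain would give in its place remains open. From the compounds shown here alone, the read-out is also the size of the effect at one concentration rather than a potency, so whether compound 3 and compound 4 would separate at lower concentrations remains unknown.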